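The source may report more compounds than this note shows. Statements on the series, on what has been measured and on what is new or still open speak of the compounds shown alone.

Measured in a functional assay on MCF7 cells (Homo sapiens) for inhibition, read by MTT assay, with a stated time of 48 h; on this read-out lower numbers stand for stronger inhibition and higher numbers for weaker inhibition:
- compound 1 (`CCOC(=O)C(=NNC1=C(C(=O)OCC)C(c2ccc(N(C)C)cc2)c2c(C)n[nH]c2N1)C(=O)OCC`): 89800 nM
- compound 2 (`CCOC(=O)C1=C(N)Nc2[nH]nc(C)c2C1c1ccc(N(C)C)cc1`): 5060 nM

Of these two, compound 2 has the lower number, and compound 1 stands well above it. The next compound, compound 3 (`CCOC(=O)C1=C(N/N=C(/Cl)C#N)Nc2[nH]nc(C)c2C1c1ccc(N(C)C)cc1`), differs from compound 2 on an amine nitrogen, with this change: a group of 5 heavy atoms (2 carbon, 2 nitrogen, 1 chlorine; no ring) in place of a hydrogen atom, on an amine nitrogen.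

Among the compounds with values here, only one measured step bears on this change: an 18-fold lower number from compound 1 to compound 2 (1.25 log units; beyond the scatter). There, a hydrogen atom in place of a larger group on an amine nitrogen went with the lower number. Read in reverse, this single pair points to a higher number once the hydrogen is replaced. Within the data shown here, the entering group is smaller than the one in compound 1, so a smaller rise is expected. The estimated change is a 3.0-fold higher number from compound 2 to compound 3 (0.47 log units; beyond the scatter) in this assay, resting on this one pair alone. For compound 3 the expected value is 15000 nM ( estimated range 3000 nM to 70000 nM).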

Compound 3, half-maximal inhibitory concentration: 23200 nM
Estimate against measurement, compound 3: 1.5-fold (0.19 log units) below; measured number inside the range.
By their numbers in this assay, from the lowest: compound 2; then compound 3; then compound 1.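

In this assay, a second and quite different entering group also goes with a higher number at this amine nitrogen, a 4.6-fold higher number from compound 2 to compound 3 (0.66 log units; beyond the scatter), so the rise on replacing the hydrogen is not confined to the large group of compound 1. The two substituted compounds also differ from each other, a 3.9-fold lower number from compound 1 to compound 3 (0.59 log units; beyond the scatter), which shows that the number depends on which group enters, with the smaller of these two groups giving the lower number. No measurement accompanying these numbers explains the differences.

On these data alone, it remains open whether a much smaller group on this nitrogen, such as a methyl or an acetyl, would stay close to compound 2. The compounds shown also leave open how the chlorine and the nitrile of the entering group each contribute to the number for compound 3.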